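A few compounds are considered here, and "the series" means these few. Any claim that something is new, unique, unknown or untested is made for them only; others in the source may bear on it.

Measured so far in the series:

compound 1 `Cc1cccc(C2(CNC(=O)Nc3c(C(C)C)cccc3C(C)C)CCCC2)c1` — 15 nM
compound 2 `CC(C)c1ccc(C2(CNC(=O)Nc3c(C(C)C)cccc3C(C)C)CCCC2)cc1` — 48 nM

Of the compounds shown here, two have been measured in an assay on microsomes for inhibition of acyl-CoA:cholesterol acyltransferase (Oryctolagus cuniculus); on this read-out higher numbers stand for weaker inhibition and lower numbers for stronger inhibition. Compound 1 stands at the lowest of the two numbers; the nearest is compound 2, and the step of a 3.2-fold higher number from compound 1 to compound 2 (0.51 log units; beyond the scatter) separates them, a change of the substituent on the phenyl ring that sits on the saturated ring carbon.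

Compound 3 `CC(C)c1cccc(C(C)C)c1NC(=O)NCC1(c2cccc(C(=O)O)c2)CCCC1` has not yet been measured. Relative to compound 1 it carries carboxy in place of methyl on an aromatic carbon. Going by the values given here, the single measured step touches the same phenyl ring, but it exchanges one substituent for another of a different kind, and it bears on the new change only in showing that this ring is not indifferent: the step of a 3.2-fold higher number from compound 1 to compound 2 (0.51 log units; beyond the scatter) was modest. Nothing measured shows what a carboxy group does here.

A higher number is expected for compound 3 in this assay, beyond the scatter, with a wide range of uncertainty. The expected step is a 5.3-fold higher number from compound 1 to compound 3 (0.73 log units; beyond the scatter). Compound 3 is thus estimated at 80 nM, in the range 15 nM to 400 nM.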

Compound 3, half-maximal inhibitory concentration: 620 nM
Beside the measured number, compound 3's estimate is 7.8-fold (0.89 log units) below it; the measured number lies above the stated range.
By their numbers in this assay, from the lowest: compound 1; then compound 2; then compound 3.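

Carboxy in place of methyl, meta to a large group, produces in this assay a change of a different order from the one seen before: a 41-fold higher number from compound 1 to compound 3 (1.62 log units; beyond the scatter), against only a 3.2-fold higher number from compound 1 to compound 2 (0.51 log units; beyond the scatter) for the earlier exchange on this phenyl ring. The 3-carboxyphenyl group also stands well apart from the 4-isopropylphenyl group, with a 13-fold higher number from compound 2 to compound 3 (1.11 log units; beyond the scatter), so the three compounds show that this ring accepts methyl and isopropyl substituents far better than carboxy, although compound 3 still gives a measurable number of 620 nM in this series. Nothing available on the compounds accounts for the size of these steps.

Still open, from the compounds shown here alone, is whether the large step belongs to the carboxy group itself or would also follow from related groups on the same aromatic carbon, such as a methyl ester, a primary amide, a hydroxymethyl group or an amine. Also open, going by these compounds, is whether a carboxy group elsewhere on the phenyl ring, or one held on a longer chain, would give a step of similar size.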